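The source may hold more compounds than are shown below. What is called first, only, known or untested is meant among the compounds shown, and "the series" means these compounds.

In a functional assay on the whole organism for positive allosteric modulation, with Mus musculus as the target (on this read-out lower numbers stand for an effect already at smaller amounts and higher numbers for an effect only at larger amounts of compound), compound 1 `CCC(=O)N(c1cccc(Cl)c1)C1CCCC1N(C)C` gives 20 mg/kg and compound 2 `CCC(=O)N(c1ccc(C)c(Cl)c1)C1CCCC1N(C)C` gives 2 mg/kg. Among the measured compounds shown here, compound 2 therefore holds the lower of the two numbers so far. For the measured compounds named here, the only measured step is a 10-fold lower number from compound 1 to compound 2 (1.00 log units; beyond the scatter), with methyl in place of hydrogen on an aromatic carbon, and it lies beyond the scatter.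

Compound 3 `CCC(=O)N(c1ccc(F)c(Cl)c1)C1CCCC1N(C)C` changes that same carbon: fluoro in place of methyl on an aromatic carbon. In words, this is fluoro in place of methyl on an aromatic carbon, ortho to a chloro group and para to a large group. Going by the values given here, no fluoro compound has been measured yet, so only the methyl-for-hydrogen result bears on this change. Among the compounds with values here, with a 10-fold lower number from compound 1 to compound 2 (1.00 log units; beyond the scatter) as the sole guide, part of that gain is expected to be lost in this assay, giving a higher number. The expected change is a 2.5-fold higher number from compound 2 to compound 3 (0.40 log units; beyond the scatter). The estimate for compound 3 is 5 mg/kg, with an expected range of 1.5 mg/kg to 18 mg/kg.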

Compound 3, dose for half-maximal effect: 0.7 mg/kg
Estimate against measurement, compound 3: 7.1-fold (0.85 log units) above; the measured number lies below the stated range.
By their numbers in this assay, from the lowest: compound 3; then compound 2; then compound 1.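

At this aromatic carbon, ortho to a chloro group and para to a large group, the gain in this assay is not confined to methyl, since fluoro in place of methyl gives a 2.9-fold lower number from compound 2 to compound 3 (0.46 log units; beyond the scatter) and so extends it. Fluoro in place of hydrogen gives a 29-fold lower number from compound 1 to compound 3 (1.46 log units; beyond the scatter) and exceeds the methyl-for-hydrogen step of a 10-fold lower number from compound 1 to compound 2 (1.00 log units; beyond the scatter) on the same carbon, which puts the three substituents in the order hydrogen, methyl, fluoro, from the highest number to the lowest. Nothing available accounts for this order or for fluoro outperforming methyl at this carbon.

Open, from the compounds shown here alone, is whether a methoxy or trifluoromethyl group on this carbon would extend the same order or break it. Also open, going by these compounds, is whether fluoro keeps its lead over methyl when the chloro group is replaced by hydrogen or the dimethylamino group by a larger amine.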